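The compounds below may be only part of what the source reports. "The series", "measured", "known", "first", "only" and "open" are said of these compounds alone.

Among the compounds with values here, compound 2, `CN(C)C(=O)/C=C/c1ccncc1-c1ccc2ccccc2c1`, gives 30.1 nM in an assay on a protein complex for inhibition of CDK8/Cyclin C (Homo sapiens), with a stated time of 1 h (on this read-out higher numbers stand for weaker inhibition and lower numbers for stronger inhibition), and this is the only number in hand, since compound 1, `NNC(=O)COc1ccncc1-c1ccc2ccccc2c1`, stands at "not determined" (no result reported) in this assay. Compound 3, `COC(=O)CCc1ccncc1-c1ccc2ccccc2c1`, differs from compound 2 in one place: 2-(methoxycarbonyl)ethyl in place of 2-(dimethylcarbamoyl)ethenyl on an aromatic carbon, which exchanges a 2-(dimethylcarbamoyl)ethenyl for a 2-(methoxycarbonyl)ethyl on an aromatic carbon. Within the data shown here, with no step between measured compounds to lean on, the expected step from compound 2 to compound 3 is an 8.3-fold higher number from compound 2 to compound 3 (0.92 log units; beyond the scatter), toward weaker inhibition and beyond the scatter. On that basis compound 3 is expected to give about 250 nM, in a range from 60 nM to 1200 nM.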

Compound 3, half-maximal inhibitory concentration: 259 nM
For compound 3 the middle estimate is 1.0-fold (0.02 log units) below the measured one, and the stated range covers the measured number.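

In this assay, the position opposite the ring nitrogen is sensitive to what it carries: replacing 2-(dimethylcarbamoyl)ethenyl with 2-(methoxycarbonyl)ethyl gives an 8.6-fold higher number from compound 2 to compound 3 (0.93 log units; beyond the scatter). This single exchange changes both the end of the chain, from dimethylcarbamoyl to methoxycarbonyl, and the number of double bonds, so the step cannot be assigned to either part alone. No further data bear on the reason for the step. From the compounds shown here alone, it remains open which part carries the step; a 2-(dimethylcarbamoyl)ethyl group would separate the two. Going by these compounds, how an amine or a carboxylic acid at this position would compare also remains open.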